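Lengthening the Sulfur-Bound Chain in a Chloromethyl Ketone Series

The compounds below may be only part of what the source reports. "The series", "measured", "known", "first", "only" and "open" are said of these compounds alone.

Measured compounds:
compound 1 `CSC[C@H](NC(C)=O)C(=O)CCl`: 30300 nM
compound 2 `CCCCSC[C@H](NC(C)=O)C(=O)CCl`: 41400 nM
compound 3 `CCCCCSC[C@H](NC(C)=O)C(=O)CCl`: 5800 nM

The three compounds share one core and differ only in the chain attached to the sulfur. In a functional assay on NALM-6 cells (Homo sapiens) (on this read-out higher numbers stand for weaker inhibition and lower numbers for stronger inhibition), compound 3 gives the lowest number of the three, and both of its steps from the others are beyond the scatter. The first lengthening of the chain, a 1.4-fold higher number from compound 1 to compound 2 (0.14 log units; within the scatter), changed nothing that can be trusted. The second, a 7.1-fold lower number from compound 2 to compound 3 (0.85 log units; beyond the scatter), brought a clear drop, and over the whole span a 5.2-fold lower number from compound 1 to compound 3 (0.72 log units; beyond the scatter) tells the same.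

Compound 4 `CCCCCCSC[C@H](NC(C)=O)C(=O)CCl` takes this one step further. The change is methyl in place of hydrogen on a saturated chain carbon, five bonds along the chain from a sulfur. The step that bears on it most directly is a 7.1-fold lower number from compound 2 to compound 3 (0.85 log units; beyond the scatter), the addition of one methyl at the chain end, which gave a marked fall; the earlier addition, a 1.4-fold higher number from compound 1 to compound 2 (0.14 log units; within the scatter), gave none. Whether the fall continues or levels off cannot be told from three points, so a small further decrease, perhaps within the scatter, is the reasonable expectation.

Compound 4 is therefore estimated at 3500 nM, with a range from 1000 nM to 12000 nM. This estimate means an expected step of a 1.7-fold lower number from compound 3 to compound 4 (0.22 log units; within the scatter).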

Compound 4, half-maximal inhibitory concentration: 3300 nM
Estimate against measurement, compound 4: 1.1-fold (0.03 log units) above; low and high end bracket the measured number.
By their numbers in this assay, from the lowest: compounds 4 and 3 (each within the scatter of the next); then compounds 1 and 2 (each within the scatter of the next).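

In this assay, adding the methyl five bonds along the chain from a sulfur gives a 1.8-fold lower number from compound 3 to compound 4 (0.24 log units; within the scatter), so this addition, unlike the one before it, brings no change that can be trusted, and compound 3 and compound 4 cannot be told apart. What the longer chain does show is that the lower numbers reached with compound 3 are kept: a 13-fold lower number from compound 2 to compound 4 (1.10 log units; beyond the scatter) and a 9.2-fold lower number from compound 1 to compound 4 (0.96 log units; beyond the scatter) both place compound 4 clearly apart from the two shorter-chain compounds, so the series looks more like a single drop followed by a flat stretch than a steady fall with each added carbon, and compound 2 goes against any steady fall. No independent measurement is available to explain why the numbers follow chain length in this way.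

The compounds shown leave open whether a longer chain, such as heptyl or octyl, would hold the number level, lower it or raise it. They also leave open how this position would respond to a chain ending in an amine or a carboxylic acid rather than in plain carbon.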